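Fluoro in place of hydrogen: the step to compound 3

The compounds below may be only part of what the source reports. "The series", "measured", "known", "first", "only" and "open" are said of these compounds alone.

Measured so far:
compound 1 `NCc1ccc(C(=O)Nc2ccncc2F)cc1-c1cccc(C(=O)OCC2CC2)c1` - 0.3 h
compound 2 `NCc1ccc(C(=O)Nc2ccncc2)cc1-c1cccc(C(=O)OCC2CCCC2)c1` - 0.517 h

In an ADME assay on a cell-free system (plasma, Homo sapiens) for metabolic stability, read by LC-MS (on this read-out higher numbers stand for a longer-lived compound and lower numbers for a shorter-lived compound), compound 2 at 0.517 h and compound 1 at 0.3 h stand within the scatter of each other. Going by the values given here, no step between measured compounds that differ in one place is available, so the series offers no direct measure of the change considered here.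

Compound 3 `NCc1ccc(C(=O)Nc2ccncc2F)cc1-c1cccc(C(=O)OCC2CCCC2)c1` follows from compound 2 by the change (fluoro in place of hydrogen on an aromatic carbon), which is fluoro in place of hydrogen on an aromatic carbon, reading pyridin-4-yl to 3-fluoropyridin-4-yl. In this assay no step beyond the scatter is expected, since compound 1 with the same 3-fluoropyridin-4-yl group gives 0.3 h within the scatter of compound 2. The expected size is a 1.3-fold lower number from compound 2 to compound 3 (0.11 log units; within the scatter) as an estimate only. For compound 3 the expected half-life is 0.4 h with an estimated range from 0.2 h to 0.8 h in repeat measurements.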

Compound 3, half-life: 0.283 h
Compound 3: the middle estimate sits 1.4-fold (0.15 log units) above what was measured; the range from low to high includes it.
By their numbers in this assay, from the lowest: compounds 3, 1 and 2 (each within the scatter of the next).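

In this assay, fluoro in place of hydrogen on an aromatic carbon, two atoms from the ring nitrogen, now has a direct reading with the cyclopentyl group held constant: the series shows a 1.8-fold lower number from compound 2 to compound 3 (0.26 log units; within the scatter) and so gives no separation at this position. With 3-fluoropyridin-4-yl held constant, cyclopentyl in place of cyclopropyl gives a 1.1-fold lower number from compound 1 to compound 3 (0.03 log units; within the scatter) and likewise separates nothing, so neither single change among these three compounds leaves the scatter. Nothing on hand bears on the cause of these readings.

Still open, as far as these compounds go, is whether the fluoro step reads the same beside groups other than cyclopentyl, and whether chloro, methyl or nitrile at this position would leave the scatter. The compounds shown also leave open how a longer chain or a carboxylic acid in place of the ester would read.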